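The compounds below may be only part of what the source reports. "The series", "measured", "known", "first", "only" and "open" are said of these compounds alone.

Compound 2 `C#Cc1cccc(Nc2ncnc3ccc(NC(=O)Nc4ccc(CN5CCN(C)CC5)cc4)cc23)c1`, tested in a functional assay on A-431 cells (Homo sapiens) for antiproliferative activity, read by MTT assay, with a stated time of 72 h (a higher number here means a weaker inhibitor, a lower number a stronger inhibitor), gives 2810 nM. Compound 1 `CN1CCN(Cc2ccc(NC(=O)Nc3ccc4ncnc(Nc5ccc(F)c(Cl)c5)c4c3)cc2)CC1` gives 4000 nM in the same assay, and the step of a 1.4-fold lower number from compound 1 to compound 2 (0.15 log units; within the scatter) is within the scatter, so the two stand side by side rather than apart. Compound 3 `CN1CCN(Cc2ccc(NC(=O)Nc3ccc4ncnc(Nc5ccc(F)c(F)c5)c4c3)cc2)CC1` differs from compound 2 by 3,4-difluorophenyl in place of 3-ethynylphenyl on a nitrogen on an aromatic ring. Among the measured compounds shown here, the one measured step that bears on this place, a 1.4-fold lower number from compound 1 to compound 2 (0.15 log units; within the scatter), also exchanged the group on this nitrogen and stayed within the scatter, so no shift beyond the scatter is expected in this assay. Compound 3 is therefore estimated at 3500 nM, between 1500 nM and 8000 nM, a step of a 1.2-fold higher number from compound 2 to compound 3 (0.10 log units; within the scatter).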

Compound 3, half-maximal inhibitory concentration: > 10000 nM
Compound 3: a limit, no number; the forecaster's own chance of this, stated with the estimate: 5%; at least 2.8-fold (0.45 log units) between middle value and limit.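

Compound 3 gives no number in this assay, only a limit of the assay: the limit of > 10000 nM in this assay, at which 1 of the 3 values shown sits. Even so, the group on this nitrogen now matters beyond the scatter, with an at least 3.5-fold higher number from compound 2 to compound 3 (0.55 log units; beyond the scatter), whereas the earlier exchange at this place stayed within it. A smaller exchange also counts, since fluoro in place of chloro on an aromatic carbon gives an at least 2.5-fold higher number from compound 1 to compound 3 (0.39 log units; beyond the scatter). Going by these compounds, how far past its limit compound 3 really lies remains open. Also open, on these data alone, is whether a nitrile or an amine in place of the ethynyl group would keep the activity of compound 2.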